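Swapping methyl for methoxy on compound 3

The source may report more compounds than this note shows. Statements on the series, on what has been measured and on what is new or still open speak of the compounds shown alone.

Of the compounds shown here, three sharing one core have been measured in a physicochemical assay for lipophilicity, using the shake flask method; on this read-out higher numbers stand for higher lipophilicity and lower numbers for lower lipophilicity. Compound 1 `Cc1ccc(NC(=O)c2cc(Oc3ccc(S(C)(=O)=O)cc3)cc(OC(C)C)c2)nc1` gives 4.05, compound 2 `CC(C)Oc1cc(Oc2ccc(S(C)(=O)=O)cc2)cc(-c2cccc(=O)[nH]2)c1` gives 2.82, and compound 3 `Cc1cnc(-c2cc(Oc3ccc(S(C)(=O)=O)cc3)cc(OC(C)C)c2)[nH]c1=O` gives 2.68. Compound 3 thus stands level with compound 2 within the scatter and clearly under compound 1.

Compound 4 `COc1cnc(-c2cc(Oc3ccc(S(C)(=O)=O)cc3)cc(OC(C)C)c2)[nH]c1=O` has not yet been measured. It differs from compound 3 in one place: methoxy in place of methyl on an aromatic carbon, para to a large group.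

For the measured compounds named here, no measured step makes this exact swap. Two large steps are known, a number 1.23 log units lower from compound 1 to compound 2 (beyond the scatter) and a number 1.37 log units lower from compound 1 to compound 3 (beyond the scatter), but each exchanges a whole group on the core, so they say little about one small substituent. The closest in kind is a number 0.14 log units lower from compound 2 to compound 3 (within the scatter), a small change within the same attached group. On the strength of that step alone, a change within the scatter is expected in this assay, with a slight drift downward at most. The expected move is a number 0.13 log units lower from compound 3 to compound 4 (within the scatter). For compound 4 the estimated value is 2.55, with an expected range from 2.2 to 2.9.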

Compound 4, distribution coefficient: 2.21
For compound 4 the middle estimate is 0.34 log units above the measured one; measured number inside the range.
By their numbers in this assay, from the lowest: compound 4; then compounds 3 and 2 (each within the scatter of the next); then compound 1.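

In this assay, the position para to a large group and two atoms from the ring nitrogen turns out to move the read-out on its own, since methoxy in place of methyl gives a step beyond the scatter (a number 0.47 log units lower from compound 3 to compound 4 (beyond the scatter)), whereas the earlier change within the attached group did not leave the scatter (a number 0.14 log units lower from compound 2 to compound 3 (within the scatter)). This small swap also separates compound 4 from the other compounds, so that it stands alone at the bottom of the series, both against the unsubstituted attached group (a number 0.61 log units lower from compound 2 to compound 4 (beyond the scatter)) and against the group of compound 1 (a number 1.84 log units lower from compound 1 to compound 4 (beyond the scatter)). Nothing at hand bears on why one added oxygen at this place goes with a step of this size.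

Only this one swap is shown at this position, so how an ethoxy chain, a chlorine atom or an amine there would read remains open. From the compounds shown here alone, whether methoxy for methyl would give a step of like size on a different attached group, or at another carbon of the same ring, remains open as well.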